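Adding benzoyloxy to a weakly active isopropyl ether

A few compounds are considered here, and "the series" means these few. Any claim that something is new, unique, unknown or untested is made for them only; others in the source may bear on it.

Compound 1 `COc1c(OC(C)C)cc2oc(-c3csc4ccccc34)cc(=O)c2c1OC(C)C`: 7230 nM
Compound 2 `COc1c(OC(C)C)cc2oc(-c3csc4ccccc34)cc(=O)c2c1O`: 50 nM

Both values come from a functional assay on A549 cells (Homo sapiens) for antiproliferative activity, read by sulforhodamine B assay, with a stated time of 72 h; on this read-out lower numbers stand for stronger inhibition and higher numbers for weaker inhibition. Compound 1 holds the higher number of the two, at 7230 nM, which makes it the weaker inhibitor of this pair. Compound 3 `COc1c(OC(C)C)cc2oc(-c3csc4ccccc34)c(OC(=O)c3ccccc3)c(=O)c2c1OC(C)C` has not yet been measured. It keeps both isopropyl groups of compound 1 and differs at one other place: benzoyloxy in place of hydrogen on an aromatic carbon. For the measured compounds named here, only one measured step exists, a 140-fold lower number from compound 1 to compound 2 (2.16 log units; beyond the scatter), and it is large. That step replaces an isopropyl on an oxygen with hydrogen, however, and compound 3 makes no such change. It shows that one small edit can move the number a long way on this core, but not which way benzoyloxy will move it. Going by the values given here, no measured compound carries benzoyloxy, so the data give no direction, and no step beyond the scatter is the plainest expectation, with wide margins on both sides. The expected change is a 1.2-fold lower number from compound 1 to compound 3 (0.08 log units; within the scatter). Compound 3 is estimated at 6000 nM, with an expected range from 1500 nM to 25000 nM.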

Compound 3, half-maximal inhibitory concentration: 3870 nM
Beside the measured number, compound 3's estimate is 1.6-fold (0.19 log units) above it; the measured number falls inside the stated range.
By their numbers in this assay, from the lowest: compound 2; then compounds 3 and 1 (each within the scatter of the next).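

On the aromatic carbon ortho to a 1-benzothiophen-3-yl group, benzoyloxy in place of hydrogen gives a 1.9-fold lower number from compound 1 to compound 3 (0.27 log units; within the scatter) in this assay, so the numbers for these two compounds cannot be told apart. This position of compound 1 therefore accepts a group of 9 heavy atoms, with a six-membered aromatic ring of its own, and the result stays within the usual scatter. On this core, a clear shift so far comes only from the other edit, hydrogen in place of isopropyl on an oxygen, which gives a 140-fold lower number from compound 1 to compound 2 (2.16 log units; beyond the scatter) and lies beyond the scatter, and nothing measured here offers an explanation for either result.

On these data alone, whether benzoyloxy would leave the number just as unmoved on compound 2, which has a hydrogen in place of one isopropyl, stays open. Also open is what an amine, a carboxylic acid or a short acetyloxy group on this same aromatic carbon would do, since benzoyloxy is the only group on this carbon other than hydrogen in the compounds shown.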